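The source may report more compounds than this note shows. Statements on the series, on what has been measured and on what is new or still open speak of the compounds shown alone.

Going by the values given here, compound 1 `Cn1c(=O)c2nc(-c3cccc(F)c3)[nH]c2n(C)c1=O` is one of two compounds so far measured in an assay for binding affinity to adenosine receptor A1 (Bos taurus) (on this read-out lower numbers stand for stronger inhibition and higher numbers for weaker inhibition), where compound 1 gives 4 nM. The other, compound 2 `CN(C)c1ccc(-c2nc3c(=O)n(C)c(=O)n(C)c3[nH]2)cc1`, gives in this assay a value of 1.8 nM; compound 1 thus stands at the higher of the two numbers, and its gap to compound 2 lies beyond the usual scatter of repeated measurements. Compound 3 `Cc1cccc(-c2nc3c(=O)n(C)c(=O)n(C)c3[nH]2)c1` has not yet been measured in this assay. It differs from compound 1 in a single place, (methyl in place of fluoro on an aromatic carbon), that is, a methyl in place of fluoro on an aromatic carbon. Among the compounds with values here, no measured pair shows this kind of exchange, so nothing comparable tells how large or in which direction the effect in this assay will be; on that basis the step of a 1.1-fold lower number from compound 1 to compound 3 (0.06 log units; within the scatter) is expected to stay within the scatter. Compound 3 is therefore estimated at 3.5 nM in this assay, with a range from 1.5 nM to 9 nM.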

Compound 3, half-maximal inhibitory concentration: 13 nM
For compound 3 the middle estimate is 3.7-fold (0.57 log units) below the measured one; measured number outside the range, above it.
By their numbers in this assay, from the lowest: compound 2; then compound 1; then compound 3.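

In this assay, the exchange at this place is not neutral: methyl in place of fluoro on an aromatic carbon gives a 3.3-fold higher number from compound 1 to compound 3 (0.51 log units; beyond the scatter) and thus moves toward weaker inhibition. The earlier compounds shown here offered no pair for reading this position, and this pair shows that it responds to the swap of one heavy atom for another, although no ring, hydrogen-bond donor, hydrogen-bond acceptor or net charge enters or leaves. No evidence on any property of these two groups bears on the result, and the size and direction of the step remain unexplained. Going by these compounds, it remains open whether a chloro, methoxy or amine group at this same place would give a number nearer that of compound 1 or that of compound 3. Also open, on these data alone, is whether the same exchange elsewhere on the ring would give a step of similar size and direction.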